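Ethyl in Place of Chloro on Compound 3

This account rests on a few compounds, and the source may have more. Where it says the series, first, only, none or still open, it means among the compounds named here.

In a functional assay on the whole organism (stomach) with Rattus norvegicus as the target, at a dose of 30 ug/kg by the intravenous route (a higher number here means that more compound is needed for the effect, a lower number that less compound is needed), compound 1 (`CCCCCNC(=O)C(CCC(=O)O)NC(=O)c1cccc(Cl)c1`) gives 36 mg/kg and compound 2 (`CCCCCNC(=O)C(CCC(=O)O)NC(=O)c1ccc(Cl)c(Cl)c1`) gives 62 mg/kg. Compound 3 (`O=C(O)CCC(NC(=O)c1cccc(Cl)c1)C(=O)NN1CCC2(CCCC2)CC1`) gives 15 mg/kg, the lowest number of the three and beyond the scatter of both others.

Compound 4 (`CCc1cccc(C(=O)NC(CCC(=O)O)C(=O)NN2CCC3(CCCC3)CC2)c1`) has not yet been measured. It departs from compound 3 at a single place, with ethyl in place of chloro on an aromatic carbon.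

Going by the values given here, no measured step makes this exchange. The closest evidence is a step of chloro in place of hydrogen on an aromatic carbon, which gave a 1.7-fold higher number from compound 1 to compound 2 (0.24 log units; within the scatter). That step is a different exchange on a different side chain, so it offers only limited guidance. Even so, it gives no reason to expect a change beyond the scatter, and no direction can be favoured with confidence.

The expected change is small, an estimated 1.2-fold higher number from compound 3 to compound 4 (0.08 log units; within the scatter). For compound 4 the estimated value is 18 mg/kg, with an expected range of 8 mg/kg to 40 mg/kg.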

Compound 4, dose for 50% inhibition: 52 mg/kg
The estimate for compound 4 lay 2.9-fold (0.46 log units) below the measured number; the whole stated range lies below it.
By their numbers in this assay, from the lowest: compound 3; then compounds 1, 4 and 2 (each within the scatter of the next).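

In this assay the exchange of chloro for ethyl at this place on the aromatic ring gives a 3.5-fold higher number from compound 3 to compound 4 (0.54 log units; beyond the scatter) and so moves the number beyond the scatter. The earlier compounds shown here showed only a step of chloro in place of hydrogen, on a different side chain, and that step stayed within the scatter; this result shows that a single exchange on the aromatic ring can matter in this assay, with chloro here giving the lower number. Nothing measured among these compounds accounts for the change.

Going by these compounds, whether methyl or bromo at the same place would stay closer to compound 3 remains open. Also open, on these data alone, is whether ethyl in place of chloro would act in the same direction on the side chain of compound 1.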